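Dimethylamino for Hydroxy on a Weakly Inhibiting Nucleoside

The source may hold more compounds than are shown below. What is called first, only, known or untested is meant among the compounds shown, and "the series" means these compounds.

Measured so far:
compound 1 `C=C1[C@@H](O)[C@H](n2cnc3c(O)nc(N)nc32)O[C@@H]1CO`: > 200000 nM
compound 2 `C=C1[C@@H](O)[C@H](n2cnc3c(N(C)C)nc(N)nc32)O[C@@H]1CO`: > 500000 nM
compound 3 `C=C1[C@H](n2cnc3c(O)nc(N)nc32)O[C@H](CO)[C@H]1O`: 8500 nM

In a functional assay on L1210 cells (Mus musculus) for inhibition (on this read-out lower numbers stand for stronger inhibition and higher numbers for weaker inhibition), compound 1 reaches only a limit, > 200000 nM. In this assay compound 2 likewise gives only a limit, > 500000 nM. The change between them is dimethylamino in place of hydroxy on an aromatic carbon, and its step, a step that the two limits leave unreadable from compound 1 to compound 2, stays unreadable because of the limit of > 200000 nM in this assay, at which 1 of the 3 values shown sits, and (the limit of > 500000 nM in this assay, at which 1 of the 3 values shown sits). Compound 3 shares its atoms with compound 1 but joins them differently; the difference between the two cores is not broken down here. In this assay compound 3 gives 8500 nM. Compound 4 `C=C1[C@H](n2cnc3c(N(C)C)nc(N)nc32)O[C@H](CO)[C@H]1O` carries the same change on the core of compound 3, (dimethylamino in place of hydroxy on an aromatic carbon). Within the data shown here, since the only measured example of this change cannot be read, the step is estimated with wide uncertainty as a 4.7-fold higher number from compound 3 to compound 4 (0.67 log units; beyond the scatter), leaning toward weaker inhibition. Compound 4 is expected to give about 40000 nM, within 6000 nM to 300000 nM.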

Compound 4, half-maximal inhibitory concentration: 454000 nM
Compound 4: middle estimate off by 11-fold (1.05 log units), on the low side; measured number outside the range, above it.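

On the core of compound 3, dimethylamino in place of hydroxy on an aromatic carbon gives a 53-fold higher number from compound 3 to compound 4 (1.73 log units; beyond the scatter) in this assay, a large loss of inhibition. On the core of compound 1 the same change cannot be read, because compound 1 gives only a limit: the limit of > 200000 nM in this assay, at which 1 of the 4 values shown sits. Compound 2 also gives only a limit, so the one readable step shows what the change does on a single core and does not show how it carries over to another: the limit of > 500000 nM in this assay, at which 1 of the 4 values shown sits.

Going by these compounds, it stays open whether methylamino or methoxy in that place would keep the inhibition of compound 3, 8500 nM. On these data alone, it is also open whether either group would give a readable number on the core of compound 1.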